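This account rests on a few compounds, and the source may have more. Where it says the series, first, only, none or still open, it means among the compounds named here.

Measured compounds:
Compound 1 `O=C(CN1CCC(N2CCCC2)CC1)C(O)(c1ccccc1)C1CCC1` — in a functional assay on ileum for antagonist activity at muscarinic acetylcholine receptor M3 (Cavia porcellus) (on this read-out higher numbers stand for weaker inhibition and lower numbers for stronger inhibition), a limit only, > 10000 nM.
Compound 2 `O=C(CN1CCN(Cc2cccs2)CC1)C(O)(c1ccccc1)C1CCC1` — in this assay 43.8 nM.
Compound 3 `C#CCN1CCN(CC(=O)C(O)(c2ccccc2)C2CCCCC2)CC1` — in this assay 260 nM.

Compound 2 stands lowest of the two numbers available; compound 3 sits well higher, beyond the usual scatter. Compound 1 gives no number at all, only the limit (the limit of > 10000 nM in this assay, at which 1 of the 3 values shown sits).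

Compound 4 `O=C(CN1CCN(Cc2ccco2)CC1)C(O)(c1ccccc1)C1CCC1` differs from compound 2 by furan-2-yl in place of thiophen-2-yl on a saturated chain carbon bound to an amine nitrogen in a ring, an exchange of one five-membered aromatic ring for another of the same kind. Among the measured compounds shown here, no step between measured compounds isolates this change, so there is no direct guide. The step from compound 2 to compound 4 is expected to be a 1.5-fold higher number from compound 2 to compound 4 (0.17 log units; within the scatter), no further than the scatter or only slightly weaker. Compound 4 is estimated at 65 nM, with a range of 25 nM to 170 nM.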

Compound 4, antagonist equilibrium constant: 750 nM
Compound 4: the middle estimate sits 12-fold (1.06 log units) below what was measured; measured number above the stated range.
By their numbers in this assay, from the lowest: compound 2; then compound 3; then compound 4. At a limit, above all of these: compound 1.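

In this assay, the ring on a saturated chain carbon bound to an amine nitrogen in a ring is not freely exchangeable: furan-2-yl in place of thiophen-2-yl gives a 17-fold higher number from compound 2 to compound 4 (1.23 log units; beyond the scatter) even though both are five-membered aromatic rings with 1 hetero atom. This rests on a single pair, so it holds only for this place on this core. Nothing measured here gives a reason for the step.

Open, going by these compounds, is how thiophen-3-yl or thiazol-2-yl would read at this place. Also open, on these data alone, is whether a benzyl group would stay with compound 2 or fall with compound 4.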